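A Methyl Group Added to Two Related Cores

The source may report more compounds than this note shows. Statements on the series, on what has been measured and on what is new or still open speak of the compounds shown alone.

Compound 1 `Cc1ccnc2nc(-c3cccc(Cl)c3)cc(O)c12` and compound 3 `Cc1cc(C)c2c(O)cc(-c3cccc(Cl)c3)nc2n1` share one core, while compound 2 `Oc1cc(-c2ccc3ccccc3c2)nc2ncccc12` carries another; the difference between the two cores is not broken down here. In a functional assay on SK-MEL-5 cells (Homo sapiens) for antiproliferative activity (a lower number here means a stronger inhibitor of growth, a higher number a weaker inhibitor of growth), compound 1 gives 41.7 nM, compound 3 gives 117 nM and compound 2 gives 3470 nM. The change methyl in place of hydrogen on an aromatic carbon produced the step of a 2.8-fold higher number from compound 1 to compound 3 (0.45 log units; beyond the scatter). Compound 4 `Cc1cnc2nc(-c3ccc4ccccc4c3)cc(O)c2c1` arises from compound 2 by the same kind of change, (methyl in place of hydrogen on an aromatic carbon), though the surroundings differ: in compound 3 the methyl sits next to the ring nitrogen and meta to a methyl group, whereas in compound 4 it sits two atoms from the ring nitrogen and no methyl group is named around it. Resting on the step of a 2.8-fold higher number from compound 1 to compound 3 (0.45 log units; beyond the scatter), a similarly modest rise is expected, a 2.4-fold higher number from compound 2 to compound 4 (0.39 log units; beyond the scatter). Compound 4 is thus estimated at 8500 nM in this assay, likely between 3000 nM and 25000 nM.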

Compound 4, concentration for 50% growth inhibition: 363 nM
Compound 4: middle estimate off by 23-fold (1.37 log units), on the high side; the whole stated range lies above it.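

In this assay, methyl in place of hydrogen on an aromatic carbon gave a 9.6-fold lower number from compound 2 to compound 4 (0.98 log units; beyond the scatter), so here the change strengthened growth inhibition. The change therefore did not carry over from one core to the other, even in direction: the same change on two cores in this assay, a 2.8-fold higher number (0.45 log units; beyond the scatter) from compound 1 to compound 3 and a 9.6-fold lower number (0.98 log units; beyond the scatter) from compound 2 to compound 4, 27-fold (1.43 log units) apart, beyond the scatter of two such steps. These two pairs show that the step on one core cannot be assumed for the other, but they do not show why, since the methyl also sits in a different place in each pair and the effects of core and position cannot be separated.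

From the compounds shown here alone, it remains open whether an ethyl group, a methoxy group or an amine on the same carbon would follow the methyl of compound 4. Also open, going by these compounds, is what a methyl at that carbon would do on the core of compound 1.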